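The source may hold more compounds than are shown below. What is called first, only, known or untested is meant among the compounds shown, and "the series" means these compounds.

compound 1 `Cc1ccc(S(=O)(=O)NC(=N)N2CCN(c3cc4c(cc3F)c(=O)c(C(=O)O)cn4C3CC3)CC2)cc1` gives 43 nM
compound 2 `N=C(NS(=O)(=O)c1ccccc1Cl)N1CCN(c2cc3c(cc2F)c(=O)c(C(=O)O)cn3C2CC2)CC1` gives 43 nM
compound 3 `N=C(NS(=O)(=O)c1cccc(Cl)c1)N1CCN(c2cc3c(cc2F)c(=O)c(C(=O)O)cn3C2CC2)CC1` gives 43 nM

All three values come from a functional assay on HL-60 cells (Homo sapiens) for antiproliferative activity, read by MTT assay, with a stated time of 72 h (a higher number here means a weaker inhibitor, a lower number a stronger inhibitor), and the three compounds differ only in the group on a sulfonyl sulfur. Compound 3, at 43 nM, stands level with compound 1 and compound 2 at the digits shown.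

Compound 4 `N=C(NS(=O)(=O)c1ccc(Cl)cc1)N1CCN(c2cc3c(cc2F)c(=O)c(C(=O)O)cn3C2CC2)CC1` has not yet been measured. It has 4-chlorophenyl in place of 3-chlorophenyl on a sulfonyl sulfur.

Three measured steps at this same place bear on the change. The closest also swaps one chlorophenyl for another and shows no change at the digits printed from compound 2 to compound 3 (within the scatter) in the measurement. Replacing 4-methylphenyl with 2-chlorophenyl shows no change at the digits printed from compound 1 to compound 2 (within the scatter), and replacing it with 3-chlorophenyl shows no change at the digits printed from compound 1 to compound 3 (within the scatter) as well.

Resting on compound 3 at 43 nM and those three steps, no step beyond the scatter is expected in this assay here. The expected outcome is no change at the digits printed from compound 3 to compound 4 (within the scatter) by this estimate. Compound 4 is estimated at 43 nM, with an expected range of 20 nM to 90 nM in repeated measurements.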

Compound 4, half-maximal inhibitory concentration: 43 nM
For compound 4 middle estimate and measured number coincide at the digits printed; the range from low to high includes it.
By their numbers in this assay, from the lowest: compounds 1, 2, 3 and 4 (each within the scatter of the next).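

In this assay the set of chlorophenyl groups on the sulfonyl sulfur is now complete: 4-chlorophenyl in place of 3-chlorophenyl gives no change at the digits printed from compound 3 to compound 4 (within the scatter), and 4-chlorophenyl in place of 2-chlorophenyl gives no change at the digits printed from compound 2 to compound 4 (within the scatter), so the three chlorophenyl isomers cannot be told apart in this assay. Within the data shown here, compound 4 also gives the first direct swap of chloro for methyl at one spot on the ring, with no change at the digits printed from compound 1 to compound 4 (within the scatter), whereas the earlier steps from compound 1 changed the chlorine's place as well as the group. Nothing measured here explains why these groups read alike.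

From the compounds shown here alone, all four compounds carry a phenyl ring with a single chloro or methyl group, so the effect of an amine or a carboxylic acid on that ring remains open. So does replacing the whole ring with a short alkyl chain such as methyl or butyl.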